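Furoquinazoline series: defluorination step carried to the diethylaminoethyl pair

A few compounds are considered here, and "the series" means these few. Any claim that something is new, unique, unknown or untested is made for them only; others in the source may bear on it.

Compound 1 `Cc1cccc(N2CCN(CCCCNc3nc(NCc4ccco4)c4cc(F)ccc4n3)CC2)c1C` and compound 2 `Cc1cccc(N2CCN(CCCCNc3nc(NCc4ccco4)c4ccccc4n3)CC2)c1C` share a core and differ only by hydrogen in place of fluoro on an aromatic carbon. In a functional assay on DU-145 cells (Homo sapiens) for cytotoxicity, read by MTT assay, with a stated time of 2 days (a higher number here means a weaker inhibitor, a lower number a stronger inhibitor), compound 1 gives 3320 nM, while compound 2 gives 1070 nM; the step of a 3.1-fold lower number from compound 1 to compound 2 (0.49 log units; beyond the scatter). Compound 3 `CCN(CC)CCNc1nc(NCc2ccco2)c2cc(F)ccc2n1` carries a different side chain; how its core differs from that of compound 1 is not broken down here, and in this assay the result for compound 3 is "not determined" (no result reported). Compound 4 `CCN(CC)CCNc1nc(NCc2ccco2)c2ccccc2n1` stands to compound 3 as compound 2 stands to compound 1: hydrogen in place of fluoro on an aromatic carbon, at the same place. With no number for compound 3, the expectation for compound 4 in this assay rests only on compound 2 at 1070 nM and on the shorter side chain, so compound 4 is estimated at 4000 nM, between 800 nM and 20000 nM.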

Compound 4, half-maximal inhibitory concentration: > 100000 nM
Compound 4: only a limit was reported; the forecaster's own chance of this, stated with the estimate: 20%; middle value at least 25-fold (1.39 log units) from the limit.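

In this assay compound 4 gives only a limit, > 100000 nM. No step can be read between compound 3 and compound 4. On these data alone, whether hydrogen in place of fluoro changes the diethylaminoethyl pair as it changes compound 1 and compound 2 stays open.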